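Loss of the 4-methoxybenzyl group from compound 2

A few compounds are considered here, and "the series" means these few. Any claim that something is new, unique, unknown or untested is made for them only; others in the source may bear on it.

Values in a functional assay on HL-60 cells (Homo sapiens) for inhibition, read by MTT assay, with a stated time of 48 h (on this read-out lower numbers stand for stronger inhibition and higher numbers for weaker inhibition), so far:
- compound 1 `COc1ccc(CO[C@H]2C=C[C@H]3C/C=C\C[C@H](c4ccc(F)cc4)OC(=O)C[C@@H]2O3)cc1` at 8830 nM
- compound 2 `COc1ccc(CO[C@H]2C=C[C@H]3C/C=C\C[C@H](c4ccc5ccccc5c4)OC(=O)C[C@@H]2O3)cc1` at 10200 nM
- compound 3 `CO[C@H]1C=C[C@H]2C/C=C\C[C@H](c3ccc(-c4ccccc4C(F)(F)F)cc3)OC(=O)C[C@@H]1O2` at 1100 nM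

Compound 2 has the highest of the three numbers, within the scatter of compound 1, while compound 3 lies clearly lower. Next is compound 4 `O=C1C[C@@H]2O[C@@H](C=C[C@@H]2O)C/C=C\C[C@H](c2ccc3ccccc3c2)O1` with hydrogen in place of 4-methoxybenzyl on an oxygen on a saturated carbon as the change, hydrogen in place of 4-methoxybenzyl on an oxygen on a saturated carbon. Among the compounds with values here, the only measured step is a 1.2-fold higher number from compound 1 to compound 2 (0.06 log units; within the scatter) with naphthalen-2-yl in place of 4-fluorophenyl, so it does not test this change. Compound 3 differs from compound 2 in more than one place, so its value cannot be assigned to this change. No step beyond the scatter is expected, with low confidence. The estimated change is a 1.3-fold lower number from compound 2 to compound 4 (0.11 log units; within the scatter) in this series. Compound 4 is expected at 8000 nM with an estimated range of 2000 nM to 30000 nM in this assay here.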

Compound 4, half-maximal inhibitory concentration: 30900 nM
The estimate for compound 4 lay 3.9-fold (0.59 log units) below the measured number; measured number above the stated range.
By their numbers in this assay, from the lowest: compound 3; then compounds 1 and 2 (each within the scatter of the next); then compound 4.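

Going from (4-methoxybenzyl)oxy to hydroxy gives a 3.0-fold higher number from compound 2 to compound 4 (0.48 log units; beyond the scatter) in this assay and is the first step read at this oxygen on a saturated carbon. The position is therefore not indifferent to this change, at least with naphthalen-2-yl on the shared core, and 4-methoxybenzyl is preferred over hydrogen in this pair. No available data explain the difference.

As far as these compounds go, it remains open whether the step holds with 4-fluorophenyl in place of naphthalen-2-yl. Also open, from the compounds shown here alone, is how an unsubstituted benzyl ether or an amine at this carbon would read.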